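A few compounds are considered here, and "the series" means these few. Any claim that something is new, unique, unknown or untested is made for them only; others in the source may bear on it.

Compound 1 `Cc1cc(C)c(CN2CCc3c(Cl)cc([C@@H](CO)[C@@H]4CCOC4)c(Cl)c3C2=O)c(=O)[nH]1`: 25.3 uL/min
Compound 2 `COC(c1cc(Cl)c2c(c1Cl)C(=O)N(Cc1c(C)cc(C)[nH]c1=O)CC2)C1CCN(C2COC2)CC1`: 78.3 uL/min; 72.7 uL/min (2 entries)

Both compounds were run in an ADME assay on microsomes from liver (Homo sapiens) for metabolic stability, read by LC-MS, using NADPH, with stated times of 10 min and 45 min, tested at 1 uM; a higher number here means faster removal of the compound, a lower number slower removal. Among the measured compounds shown here, compound 1 gives 25.3 uL/min, the only single reading in the set, whereas compound 2 was run more than once the several entries of compound 2 in this assay, 78.3 uL/min; 72.7 uL/min (2 entries) and gives 78.3 uL/min; 72.7 uL/min (2 entries), a higher reading than compound 1. For the measured compounds named here, no two measured compounds differ from each other in one place, so no step size between neighbours has yet been seen in this assay.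

Compound 3 `Cc1cc(C)c(CN2CCc3c(Cl)cc([C@H](CO)[C@@H]4CCCO4)c(Cl)c3C2=O)c(=O)[nH]1` has not yet been tested. It is built from the same atoms as compound 1, joined differently: a group of 8 heavy atoms (6 carbon, 2 oxygen; one five-membered non-aromatic ring with 1 hetero atom) in place of a group of 8 heavy atoms (6 carbon, 2 oxygen; one five-membered non-aromatic ring with 1 hetero atom), on an aromatic carbon. The five-membered ring with one hetero atom is kept but attached through a different carbon, and the two stereocentres are redefined. Going by the values given here, no measured pair speaks to a rearrangement of this kind, so the expectation rests on compound 1 alone. The step from compound 1 to compound 3 is expected to be small, within the usual scatter, with a slight lean toward faster removal: a 1.3-fold higher number from compound 1 to compound 3 (0.10 log units; within the scatter). Compound 3 is therefore expected to give about 32 uL/min, somewhere between 15 uL/min and 65 uL/min.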

Compound 3, intrinsic clearance in a liver preparation (reported as CLH), per the amount of preparation that the assay uses: 37.6 uL/min
Compound 3: middle estimate off by 1.2-fold (0.07 log units), on the low side; low and high end bracket the measured number.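

In this assay, rearranging the group on the aromatic carbon ortho to a chloro group gives a 1.5-fold higher number from compound 1 to compound 3 (0.17 log units; within the scatter), the first step seen at this position. Compound 1 and compound 3 therefore cannot be told apart by this measurement, which shows that the same atoms can be joined differently here, keeping a five-membered non-aromatic ring with 1 hetero atom, without a step beyond the usual scatter. Repeat readings give a sense of how closely two entries for one compound can agree, as in: the several entries of compound 2 in this assay, 78.3 uL/min; 72.7 uL/min (2 entries)

This single step combines a different ring attachment with redefined stereocentres, so the compounds shown cannot separate the contribution of either, and a step within the scatter could hide small opposing contributions. They also leave open how removal would respond to a truly different group on this aromatic carbon, such as a carboxylic acid or a longer chain, since both compounds here carry the same atoms at this position.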